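Replacing a benzyl ester with a dimethylamide at the cinnamate end

The compounds below may be only part of what the source reports. "The series", "measured", "known", "first", "only" and "open" are said of these compounds alone.

Compound 1, `CCOC(=O)/C=C/c1ccc(CN(C(=O)C2CCCCC2)c2cccc(/C=C/C(=O)OC)c2)cc1` — in an assay on isolated protein with Bile acid receptor (Homo sapiens) as the target (on this read-out lower numbers stand for an effect already at smaller amounts and higher numbers for an effect only at larger amounts of compound), it reaches > 1000 nM, a limit of the assay.
Compound 2, `COC(=O)/C=C/c1cccc(N(Cc2ccc(/C=C/C(=O)OCc3ccccc3)cc2)C(=O)C2CCCCC2)c1` — compound 2 gives > 1000 nM, also a limit of the assay.

Going by these compounds, compound 2 stands at a limit and not at a number, so its true position is unknown beyond that boundary. Within the data shown here, the only measured step, a step that the two limits leave unreadable from compound 1 to compound 2, joins two limits and cannot be read; this is the limit of > 1000 nM in this assay, at which 2 of the 2 values shown sit.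

Compound 3, `COC(=O)/C=C/c1cccc(N(Cc2ccc(/C=C/C(=O)N(C)C)cc2)C(=O)C2CCCCC2)c1`, differs from compound 2 by dimethylamino in place of benzyloxy on a carbonyl carbon. Among the measured compounds shown here, no measured step shows what such a change does, and the two measured values give no readable direction. The expectation for compound 3 therefore rests on compound 2 sitting at > 1000 nM: the most likely outcome is another limit. Compound 3 is estimated at 3000 nM, with a range from 800 nM to 30000 nM. The expected step is a step that the limit leaves unreadable from compound 2 to compound 3, which is not readable as a real change.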

Compound 3, half-maximal effective concentration: > 1000 nM
Compound 3 ended at the assay's limit (the forecaster's own chance of this, stated with the estimate: 80%); the middle value is on the limit's open side.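

The steps among compound 1, compound 2 and compound 3 cannot be read, because all three compounds stand at a limit and not at a number: the limit of > 1000 nM in this assay, at which 3 of the 3 values shown sit.

Left open is whether ethoxy, benzyloxy and dimethylamino on this carbonyl carbon differ at all in their effect.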